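Trifluoromethyl for Fluoro, Tried on a Second Core

This account rests on a few compounds, and the source may have more. Where it says the series, first, only, none or still open, it means among the compounds named here.

Compound 1, `CN1C/C(=C\c2ccncc2)C(=O)/C(=C/c2ccccc2F)C1`: 14900 nM
Compound 2, `CN1C/C(=C\c2ccncc2)C(=O)/C(=C/c2ccccc2C(F)(F)F)C1`: 15800 nM
Compound 3, `O=C1/C(=C/c2cccnc2)CNC/C1=C\c1ccccc1F`: 15900 nM

All three were measured in an ADME assay on L02 cells (Homo sapiens) for cytotoxicity, read by MTT assay, with a stated time of 24 h; a lower number here means a stronger inhibitor, a higher number a weaker inhibitor. Compound 1 gives 14900 nM and compound 2 gives 15800 nM. Between them lies a single change, (trifluoromethyl in place of fluoro on an aromatic carbon), and the step it made was a 1.1-fold higher number from compound 1 to compound 2 (0.03 log units; within the scatter). Compound 3 sits on a different core and gives 15900 nM; the difference between its core and the core of compound 1 is not broken down here. The three numbers lie close together, so none of them can be called stronger or weaker than another.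

Compound 4, `O=C1/C(=C/c2cccnc2)CNC/C1=C\c1ccccc1C(F)(F)F`, has not yet been measured. Within the data shown here, it differs from compound 3 by trifluoromethyl in place of fluoro on an aromatic carbon, which is the same change as the one from compound 1 to compound 2, at the same kind of place. Since that earlier step a 1.1-fold higher number from compound 1 to compound 2 (0.03 log units; within the scatter) stayed within the scatter, the step in this assay is expected to be about as small: a 1.0-fold higher number from compound 3 to compound 4 (0.02 log units; within the scatter). Compound 4 is therefore estimated at 16500 nM, most likely between 9000 nM and 30000 nM. A single earlier example is a thin basis, so the range is kept wide.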

Compound 4, half-maximal inhibitory concentration: 11300 nM
Beside the measured number, compound 4's estimate is 1.5-fold (0.16 log units) above it, within the range that was stated.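

In this assay, trifluoromethyl in place of fluoro on the second core gave a 1.4-fold lower number from compound 3 to compound 4 (0.15 log units; within the scatter) and this step lies inside the normal spread of repeated measurements, so it cannot be read as a real shift in either direction. The step on the first core also lies inside that spread, and the two steps cannot be told apart, so across these four compounds the swap has no detectable effect on either core: the same change on two cores in this assay, a 1.1-fold higher number (0.03 log units; within the scatter) from compound 1 to compound 2 and a 1.4-fold lower number (0.15 log units; within the scatter) from compound 3 to compound 4, 1.5-fold (0.17 log units) apart, within the scatter of two such steps. Among these compounds, this shows only that the step stayed small on two cores in this assay; it does not show that the two cores respond identically, since a modest difference could hide within the scatter, and it says nothing about a third core.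

All four compounds carry either fluoro or trifluoromethyl on that aromatic carbon. On these data alone, how a very different group there, such as an amine, a carboxylic acid or a longer chain, would behave remains open.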